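Replacing 2-Fluorophenyl with 4-Methylphenyl

A few compounds are considered here, and "the series" means these few. Any claim that something is new, unique, unknown or untested is made for them only; others in the source may bear on it.

Compound 1 `NS(=O)(=O)c1ccc(N2N=C(c3ccccc3)CC2c2ccccc2F)cc1` gives 28000 nM in an ADME assay on Vero 76 cells (Chlorocebus sabaeus) for cytotoxicity, read by MTT assay, with a stated time of 96 h (a higher number here means that more compound is tolerated, a lower number that less compound is tolerated), and so holds the lower of the two numbers available. Compound 2 `Cc1ccccc1C1CC(c2ccc(OCc3ccccc3)cc2)=NN1c1ccc(S(N)(=O)=O)cc1` gives 100000 nM in the same test and differs from compound 1 in more than one place. Among the measured compounds shown here, the next step leads to compound 3 `Cc1ccc(C2CC(c3ccccc3)=NN2c2ccc(S(N)(=O)=O)cc2)cc1` with 4-methylphenyl in place of 2-fluorophenyl on a saturated ring carbon as its only change. For the measured compounds named here, no measured pair differs in a single place, so nothing yet shows directly what such a swap does, and any forecast is tentative. The higher number of compound 2 at 100000 nM gives only a weak hint of upward room. The estimated step is a 1.4-fold higher number from compound 1 to compound 3 (0.15 log units; within the scatter) and would be a small rise within the usual scatter. In this assay compound 3 is expected to give 40000 nM with 15000 nM to 100000 nM as its likely range.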

Compound 3, half-maximal cytotoxic concentration: 20000 nM
The estimate for compound 3 lay 2.0-fold (0.30 log units) above the measured number, within the range that was stated.
By their numbers in this assay, from the lowest: compounds 3 and 1 (each within the scatter of the next); then compound 2.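

Among the compounds shown here, this is the first pair that differs in one place, so the swap of 2-fluorophenyl for 4-methylphenyl on a saturated ring carbon can now be read directly in this assay (a 1.4-fold lower number from compound 1 to compound 3 (0.15 log units; within the scatter)). At this position, the two groups cannot be told apart by this read-out, even though a fluorine atom leaves and a seventh carbon enters. Nothing measured here bears on what lies behind this result.

As far as these compounds go, it remains open whether a phenyl ring carrying an amine or a carboxylic acid at this ring carbon would move the number beyond the scatter. Compound 2 differs from compound 1 in more than one place, so its higher number cannot be tied to any single group, including the benzyloxy-bearing ring it carries.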